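The source may report more compounds than this note shows. Statements on the series, on what has been measured and on what is new or still open speak of the compounds shown alone.

Compound 1 `Nc1scc(CN2CCN(c3ccc(Cl)cc3F)CC2)c1C(=O)c1ccc(Cl)cc1` is one of three close relatives that share a core and differ only in the aryl group carried on the amine nitrogen in a ring. In an assay on CHO cells for displacement of a labelled ligand from adenosine receptor A1 (Homo sapiens), read by scintillation counting, with a stated time of 120 min, tested at 10 uM (a higher number here means more inhibition at the concentration tested (going by the name of the read-out), a lower number less inhibition), compound 1 gives 0%, and on this number it stands level with compounds 2 and 3. Compound 2 `Nc1scc(CN2CCN(c3ccccc3C(F)(F)F)CC2)c1C(=O)c1ccc(Cl)cc1` gives 0% in this assay. Compound 3 `Nc1scc(CN2CCN(c3ccc(Cl)c(C(F)(F)F)c3)CC2)c1C(=O)c1ccc(Cl)cc1` gives 0% in this assay. The three steps among them, no change at the digits printed from compound 1 to compound 2 (within the scatter), no change at the digits printed from compound 1 to compound 3 (within the scatter) and no change at the digits printed from compound 2 to compound 3 (within the scatter), all swap one aryl group for another at the same position and none moves the read-out beyond the scatter.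

Compound 4 `Nc1scc(CN2CCN(c3cccc(F)c3)CC2)c1C(=O)c1ccc(Cl)cc1` is not yet measured. It differs from compound 1 in one place: 3-fluorophenyl in place of 4-chloro-2-fluorophenyl on an amine nitrogen in a ring. This is a change of the same kind as the three measured steps, which bear on it directly and were all flat, so the step of no change at the digits printed from compound 1 to compound 4 (within the scatter) is expected to be none beyond the scatter. Compound 4 is therefore estimated at 0% in this assay, with a range from -8% to 10%.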

Compound 4, a percentage reported as inhibition, at one concentration (the size of the read-out at that concentration, not a potency): 1%
For compound 4 the middle estimate is 1 percentage points below the measured one, and the stated range covers the measured number.
By their numbers in this assay, from the lowest: compounds 1, 2, 3 and 4 (each within the scatter of the next).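

With 3-fluorophenyl on the amine nitrogen in a ring, the series now includes an aryl group with one fewer heavy atom and no chlorine, and the step in this assay is a number 1 percentage points higher from compound 1 to compound 4 (within the scatter). Aryl groups carrying trifluoromethyl can also be set against one without it, giving a number 1 percentage points higher from compound 2 to compound 4 (within the scatter) and a number 1 percentage points higher from compound 3 to compound 4 (within the scatter), so all four aryl groups at this position sit within the scatter of one another. Nothing available explains this flat result.

All four aryl groups carry only fluorine, chlorine or trifluoromethyl, which leaves open whether a phenyl ring bearing a methoxy group, an amine or a carboxylic acid would give a different reading. With all four readings so close together, the compounds also leave open whether any change at this position matters in this assay.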